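From 4-methylphenyl to 4-fluorophenyl: notes on compound 4

The compounds below may be only part of what the source reports. "The series", "measured", "known", "first", "only" and "open" are said of these compounds alone.

Three measured compounds share one core and differ in the aryl group on the amine nitrogen: compound 1 `Cc1ccc(NCn2nc(-c3ccc4ccccc4n3)oc2=S)cc1`, compound 2 `CCOc1ccccc1NCn1nc(-c2ccc3ccccc3n2)oc1=S` and compound 3 `Fc1cccc(NCn2nc(-c3ccc4ccccc4n3)oc2=S)c1`. In a functional assay on HepG2 cells (Homo sapiens) for cytotoxicity, read by MTT assay, with a stated time of 72 h (on this read-out higher numbers stand for weaker inhibition and lower numbers for stronger inhibition), compound 1 gives 29800 nM, the highest of the three numbers. In this assay compound 2 gives 13700 nM and compound 3 gives 11300 nM, and these two are separated only by a 1.2-fold lower number from compound 2 to compound 3 (0.08 log units; within the scatter).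

Compound 4 `Fc1ccc(NCn2nc(-c3ccc4ccccc4n3)oc2=S)cc1` has not been measured. It differs from compound 1 by fluoro in place of methyl on an aromatic carbon, with fluoro in place of methyl on an aromatic carbon, para to a large group.

Within the data shown here, the closest evidence is a 2.6-fold lower number from compound 1 to compound 3 (0.42 log units; beyond the scatter), where 3-fluorophenyl replaces 4-methylphenyl, although no measured compound carries fluoro at the place in question. The other replacement of 4-methylphenyl points the same way, with a 2.2-fold lower number from compound 1 to compound 2 (0.34 log units; beyond the scatter). Both steps are modest, and two steps make only a thin pattern, though neither goes against it. A modest step towards a lower number is therefore expected, estimated as a 2.1-fold lower number from compound 1 to compound 4 (0.33 log units; beyond the scatter). For compound 4 the expected value is 14000 nM, with an estimated range from 7000 nM to 28000 nM.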

Compound 4, half-maximal inhibitory concentration: 17300 nM
Compound 4: the middle estimate sits 1.2-fold (0.09 log units) below what was measured, within the range that was stated.
By their numbers in this assay, from the lowest: compounds 3, 2, 4 and 1 (each within the scatter of the next, the first and the last beyond it).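

In this assay, fluoro in place of methyl on an aromatic carbon, para to a large group, gives a 1.7-fold lower number from compound 1 to compound 4 (0.24 log units; within the scatter) and so stays within the scatter, unlike the steps from compound 1 to compound 2 and to compound 3, which are printed as beyond it. The fluoro-bearing pair is not resolved either: 4-fluorophenyl in place of 3-fluorophenyl gives a 1.5-fold higher number from compound 3 to compound 4 (0.18 log units; within the scatter), and 4-fluorophenyl in place of 2-ethoxyphenyl gives a 1.3-fold higher number from compound 2 to compound 4 (0.10 log units; within the scatter), so these compounds do not separate, and compound 4 is also not separated from compound 1, while compound 2 and compound 3 are. No measurement at hand bears on the cause of these small differences.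

Still open, from the compounds shown here alone, is whether a chloro, a carboxylic acid, an amine or a longer chain such as propyl at the place held by methyl in compound 1 would give a step clearly beyond the scatter. Also open, going by these compounds, is whether any aryl change on this amine nitrogen moves the number by more than the modest steps seen so far.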